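From methylcarbamoyl to dimethylcarbamoyl: working notes on compound 4

The source may report more compounds than this note shows. Statements on the series, on what has been measured and on what is new or still open speak of the compounds shown alone.

Values so far in a functional assay on the whole organism with Mus musculus as the target, in the rotarod test; a lower number here means that less compound is needed, a higher number that more compound is needed for the effect:
- compound 1 `Cc1cc(Cl)ccc1-c1ccc(N2CCC(O)CC2)nn1`: 64 mg/kg
- compound 2 `O=COC1CCN(c2ccc(-c3ccc(Cl)cc3Cl)nn2)CC1`: 69 mg/kg
- compound 3 `CNC(=O)OC1CCN(c2ccc(-c3ccccc3Cl)nn2)CC1`: 37 mg/kg

Compound 3 lies within the scatter of both compound 1 and compound 2 in this assay so no order among the three can be read. Compound 4 `CN(C)C(=O)OC1CCN(c2ccc(-c3ccccc3Cl)nn2)CC1` differs from compound 3 at one place: methyl in place of hydrogen on an amide-type nitrogen with methyl in place of hydrogen on an amide-type nitrogen. Among the compounds with values here, no measured pair shows this change, and nothing here fixes a direction. No step beyond the scatter is expected. The estimated step is a 1.2-fold higher number from compound 3 to compound 4 (0.09 log units; within the scatter) and it stays within the scatter. For compound 4 the estimated value is 45 mg/kg with an expected range from 22 mg/kg to 90 mg/kg as the working figure.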

Compound 4, dose for half-maximal effect: 8.4 mg/kg
For compound 4 the middle estimate is 5.4-fold (0.73 log units) above the measured one, and the stated range ends above it.
By their numbers in this assay, from the lowest: compound 4; then compounds 3, 1 and 2 (each within the scatter of the next).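

In this assay, within the data shown here, the change from (methylcarbamoyl)oxy to (dimethylcarbamoyl)oxy, methyl in place of hydrogen on the amide-type nitrogen, gives a 4.4-fold lower number from compound 3 to compound 4 (0.64 log units; beyond the scatter) and is the only step so far that lies beyond the scatter. This nitrogen is therefore a place where a single added methyl moves the number, and the lower number goes with the dimethylcarbamoyl group. Nothing available accounts for the step. As far as these compounds go, whether a longer chain such as ethyl on this nitrogen goes further remains open, as does whether the same step holds on the core of compound 2.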